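Fluoro in place of methyl: from compound 2 to compound 4

The source may report more compounds than this note shows. Statements on the series, on what has been measured and on what is new or still open speak of the compounds shown alone.

Measured so far in a functional assay on MCF7 cells (Homo sapiens) for cytotoxicity, read by MTT assay, with a stated time of 96 h; a higher number here means a weaker inhibitor, a lower number a stronger inhibitor:
compound 1 `COc1cc(C(=O)c2cn(-c3ccccc3)cc2-c2ccccc2[N+](=O)[O-])cc(OC)c1OC` gives 49 nM
compound 2 `COc1cc(C(=O)c2cn(-c3cccc(C)c3)cc2-c2ccccc2[N+](=O)[O-])cc(OC)c1OC` gives 220 nM
compound 3 `COc1cc(C(=O)c2cn(-c3cccc(C)c3)cc2-c2cccc([N+](=O)[O-])c2)cc(OC)c1OC` gives 880 nM

Compound 2 holds the middle of the three numbers, with compound 1 lower and compound 3 higher, both gaps beyond the scatter. Compound 4 `COc1cc(C(=O)c2cn(-c3cccc(F)c3)cc2-c2ccccc2[N+](=O)[O-])cc(OC)c1OC` is not yet measured. It differs from compound 2 by fluoro in place of methyl on an aromatic carbon, that is 3-methylphenyl to 3-fluorophenyl: fluoro in place of methyl on an aromatic carbon.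

The nearest evidence is the modest step of a 4.5-fold higher number from compound 1 to compound 2 (0.65 log units; beyond the scatter) on going from hydrogen to methyl at the same place. The step of a 4.0-fold higher number from compound 2 to compound 3 (0.60 log units; beyond the scatter) concerns the nitrophenyl group instead and gives only a sense of scale. Among the measured compounds shown here, no fluoro compound has been measured, so the expectation rests on the first step alone. Part of that step is expected to be undone in this assay when methyl leaves. The expected change is a 2.2-fold lower number from compound 2 to compound 4 (0.34 log units; beyond the scatter) as a modest move towards a lower number. For compound 4 the estimated value is 100 nM within an expected range of 35 nM to 280 nM.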

Compound 4, half-maximal inhibitory concentration: 190 nM
Estimate against measurement, compound 4: 1.9-fold (0.28 log units) below; low and high end bracket the measured number.
By their numbers in this assay, from the lowest: compound 1; then compounds 4 and 2 (each within the scatter of the next); then compound 3.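

In this assay, the series gives a 1.2-fold lower number from compound 2 to compound 4 (0.06 log units; within the scatter), so methyl and fluoro cannot be told apart at this position. Against hydrogen, fluoro gives a 3.9-fold higher number from compound 1 to compound 4 (0.59 log units; beyond the scatter), which makes it the second group here, after methyl with a 4.5-fold higher number from compound 1 to compound 2 (0.65 log units; beyond the scatter), to carry a higher number than compound 1. No available measurement bears on why methyl and fluoro read alike.

Still open, going by these compounds, is whether the higher number seen with both groups extends to other groups at this position, such as a chlorine atom, an amine or a carboxylic acid. Also open, on these data alone, is whether the 3-fluorophenyl compound responds to 3-nitrophenyl in place of 2-nitrophenyl as the 3-methylphenyl pair does in a 4.0-fold higher number from compound 2 to compound 3 (0.60 log units; beyond the scatter).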